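This account rests on a few compounds, and the source may have more. Where it says the series, first, only, none or still open, it means among the compounds named here.

Among the measured compounds shown here, compound 2 `Cc1nnc(SCC(=O)Nc2ccc(-c3nc(-c4ccccc4)c(-c4ccccc4)n3C)cc2)s1` gives 73% in a functional assay on HT-29 cells (Homo sapiens) for cytotoxicity, read by MTT assay, with a stated time of 24 h, tested at 6.4 ug/mL (a lower number here means a weaker effect, a higher number a stronger effect of the compound at the concentration tested), the higher of the two numbers measured so far, and compound 1 `Cc1ccc2oc(SCC(=O)Nc3ccc(-c4nc(-c5ccccc5)c(-c5ccccc5)n4C)cc3)nc2c1` gives 25.6% in this assay. For the measured compounds named here, the one measured step, a number 47.4 percentage points higher from compound 1 to compound 2 (beyond the scatter), shows that exchanging the ring on the sulfur alone moves the read-out far. Compound 3 `Cn1c(-c2ccc(NC(=O)CN3CCN(c4ccccc4)CC3)cc2)nc(-c2ccccc2)c1-c1ccccc1` differs from compound 2 by 4-phenylpiperazin-1-yl in place of (5-methyl-1,3,4-thiadiazol-2-yl)sulfanyl on a saturated chain carbon bound to a carbonyl carbon. Going by the values given here, no measured step bears directly on this change: the measured step kept the sulfur and exchanged only the ring on it, whereas here the whole sulfur-linked group gives way to a group without sulfur. Because one exchange at this place already produced a number 47.4 percentage points higher from compound 1 to compound 2 (beyond the scatter), a large step in either direction is possible for compound 3. The estimate for compound 3 is therefore 45%, between 15% and 80%, which corresponds to an expected step of a number 28 percentage points lower from compound 2 to compound 3 (beyond the scatter).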

Compound 3, a percentage reported as activity, at one concentration (the size of the read-out at that concentration, not a potency): 46.5%
Compound 3: middle estimate off by 1.5 percentage points, on the low side; measured number inside the range.
By their numbers in this assay, from the lowest: compound 1; then compound 3; then compound 2.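

With 4-phenylpiperazin-1-yl on the saturated chain carbon bound to a carbonyl carbon, this assay shows a number 26.5 percentage points lower from compound 2 to compound 3 (beyond the scatter) and also a number 20.9 percentage points higher from compound 1 to compound 3 (beyond the scatter). The group without sulfur thus lands between the two sulfur-linked groups, so at this place the presence of a sulfanyl group does not by itself set the read-out, and a larger group with a non-aromatic ring still leaves a clear effect. Nothing in the data given explains these differences. As far as these compounds go, it remains open whether the phenyl ring of the new group counts, which 4-methylpiperazin-1-yl or morpholin-4-yl at this place would test. From the compounds shown here alone, it also remains open whether the sulfur matters apart from the ring it carries, which an oxygen link to 5-methyl-1,3,4-thiadiazol-2-yl would separate.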